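From thiophen-2-yl to thiophen-3-yl on the saturated ring carbon

A few compounds are considered here, and "the series" means these few. Any claim that something is new, unique, unknown or untested is made for them only; others in the source may bear on it.

Of the compounds shown here, three have been measured in an assay on membranes from HeLa cells for displacement of a labelled ligand from adenosine receptor A3 (Homo sapiens), read by scintillation counting, with a stated time of 180 min, tested at 1 uM; a lower number here means less inhibition, a higher number more inhibition at the concentration tested (going by the name of the read-out). Compound 1 `CCCOC(=O)C1=C(C)NC(=O)NC1c1ccsc1` gives 6%. Compound 2 `CC1=C(C(N)=O)C(c2ccsc2)NC(=O)N1` gives 1%, a step of a number 5 percentage points lower from compound 1 to compound 2 (within the scatter). Compound 3 `CC1=C(c2ncc(C)o2)C(c2cccs2)NC(=O)N1` gives 1%, level with compound 2 at the digits shown and together with it the lowest of the three numbers; its gap to compound 1 is within the scatter.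

Compound 4 `CC1=C(c2ncc(C)o2)C(c2ccsc2)NC(=O)N1` differs from compound 3 by thiophen-3-yl in place of thiophen-2-yl on a saturated ring carbon. Going by the values given here, no measured step touches this change; the single measured step, a number 5 percentage points lower from compound 1 to compound 2 (within the scatter), concerns a different place and was within the scatter. Because compound 3 gives 1%, compound 4 is expected at 3%, with a range from 0% to 15%. The expected step of a number 2 percentage points higher from compound 3 to compound 4 (within the scatter) is estimated to lie within the scatter.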

Compound 4, a percentage reported as inhibition, at one concentration (the size of the read-out at that concentration, not a potency): 2%
Estimate against measurement, compound 4: 1 percentage points above, within the range that was stated.
By their numbers in this assay, from the lowest: compounds 2, 3, 4 and 1 (each within the scatter of the next).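

Thiophen-3-yl in place of thiophen-2-yl on the saturated ring carbon gives a number 1 percentage points higher from compound 3 to compound 4 (within the scatter) in this assay, so moving the attachment point of the thiophene produces no readable change here. On the double-bonded ring carbon, 5-methyl-1,3-oxazol-2-yl gives a number 1 percentage points higher from compound 2 to compound 4 (within the scatter) against carbamoyl and a number 4 percentage points lower from compound 1 to compound 4 (within the scatter) against propoxycarbonyl, so these three groups cannot be told apart. No evidence is available that bears on these results.

From the compounds shown here alone, all four numbers lie within the scatter of each other at a single concentration, so what would move this read-out stays open. Going by these compounds, whether phenyl on the saturated ring carbon or a carboxylic acid on the double-bonded ring carbon would read differently also remains open.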